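This account rests on a few compounds, and the source may have more. Where it says the series, first, only, none or still open, it means among the compounds named here.

Compound 1 `Nc1scc(CN2CCN(c3cccc(Cl)c3Cl)CC2)c1C(=O)c1ccc(Cl)cc1` gives 2% in an assay on CHO cells for displacement of a labelled ligand from adenosine receptor A1 (Homo sapiens), read by scintillation counting, with a stated time of 120 min, tested at 10 uM; a higher number here means more inhibition at the concentration tested (going by the name of the read-out), a lower number less inhibition. Compound 2 `Nc1scc(CN2CCN(c3ccc(F)cc3F)CC2)c1C(=O)c1ccc(Cl)cc1` gives 1% in this assay.

Compound 2 shows the lowest of the two numbers in this assay, with compound 1 the nearest and the step from compound 1 to compound 2 a number 1 percentage points lower from compound 1 to compound 2 (within the scatter). Both values sit close to zero, so the shared core with a substituted phenyl on the ring nitrogen has shown essentially no inhibition at the concentration tested in either case.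

Compound 3 `Nc1scc(CN2CCN(c3c(F)cccc3F)CC2)c1C(=O)c1ccc(Cl)cc1` differs from compound 2 in one place: 2,6-difluorophenyl in place of 2,4-difluorophenyl on an amine nitrogen in a ring. For the measured compounds named here, the only measured step that bears on this change, the exchange of one substituted phenyl for another at the same ring nitrogen, was within the scatter. Compound 3 is therefore expected to stay near the floor, with the step from compound 2 to compound 3 a number 2 percentage points higher from compound 2 to compound 3 (within the scatter) expected to be nothing beyond the scatter. The estimate for compound 3 is 3%, within -5% to 12%.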

Compound 3, a percentage reported as inhibition, at one concentration (the size of the read-out at that concentration, not a potency): 1%
Beside the measured number, compound 3's estimate is 2 percentage points above it; the measured number falls inside the stated range.
By their numbers in this assay, from the lowest: compounds 2, 3 and 1 (each within the scatter of the next).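

With the same atoms joined differently, the ring carried on the amine nitrogen in a ring now shows that moving a fluorine within the difluorophenyl group does not register in this assay: 2,6-difluorophenyl in place of 2,4-difluorophenyl gives no change at the digits printed from compound 2 to compound 3 (within the scatter). Set against the 2,3-dichlorophenyl group, the same 2,6-difluorophenyl group gives a number 1 percentage points lower from compound 1 to compound 3 (within the scatter), so all three halogen-bearing phenyl groups at this position now lie within the scatter of one another. Nothing available explains these near-zero numbers.

Whether any group on this ring nitrogen can raise the number remains open, since a benzyl group, a pyridine ring or an acetyl group is not among those shown. The compounds shown also leave open whether a change elsewhere in the shared core would do so.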